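Swapping Trifluoromethyl for Fluoro on a Second Core

The source may report more compounds than this note shows. Statements on the series, on what has been measured and on what is new or still open speak of the compounds shown alone.

Measured compounds:
compound 1, `CCC(c1nc2ncc(Cl)cc2[nH]1)[C@H]1CC[C@@H](c2ccnc3ccc(C(F)(F)F)cc32)CC1`: 81%
compound 2, `CCC(Nc1nnc(-c2ccc(OC)cc2)o1)[C@H]1CC[C@@H](c2ccnc3ccc(C(F)(F)F)cc32)CC1`: 83%
compound 3, `CCC(c1nc2ncc(Cl)cc2[nH]1)[C@H]1CC[C@@H](c2ccnc3ccc(F)cc32)CC1`: 78%

The three compounds were run in an ADME assay on microsomes from liver (Homo sapiens) for metabolic stability, with a stated time of 10 min, tested at 0.5 uM; on this read-out higher numbers stand for a more stable compound and lower numbers for a less stable compound. Compound 1 gives 81% there, compound 2 gives 83% and compound 3 gives 78%. All three numbers lie within the scatter of one another, so none can be called more or less stable than the others.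

Compound 3 is compound 1 with one change, (fluoro in place of trifluoromethyl on an aromatic carbon), and the measured step is a number 3 percentage points lower from compound 1 to compound 3 (within the scatter). How the core of compound 2 differs from the core of compound 1 is not broken down here.

Compound 4, `CCC(Nc1nnc(-c2ccc(OC)cc2)o1)[C@H]1CC[C@@H](c2ccnc3ccc(F)cc32)CC1`, has not yet been measured. It stands to compound 2 as compound 3 stands to compound 1: the change is fluoro in place of trifluoromethyl on an aromatic carbon, the same change at the same place. Because the first instance gave a number 3 percentage points lower from compound 1 to compound 3 (within the scatter), the step from compound 2 to compound 4 is expected to be a number 3 percentage points lower from compound 2 to compound 4 (within the scatter). Compound 4 is therefore estimated at 80%, between 68% and 90%, in this assay.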

Compound 4, percent of the compound remaining: 66%
For compound 4 the middle estimate is 14 percentage points above the measured one; measured number below the stated range.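

In this assay, fluoro in place of trifluoromethyl on an aromatic carbon gives a number 17 percentage points lower from compound 2 to compound 4 (beyond the scatter). Set beside the earlier instance, the two steps cannot be told apart, even though only this one lies beyond the scatter when read alone: the same change on two cores in this assay, a number 3 percentage points lower (within the scatter) from compound 1 to compound 3 and a number 17 percentage points lower (beyond the scatter) from compound 2 to compound 4, 14 percentage points apart, within the scatter of two such steps. The change therefore lowers the number clearly on the core of compound 2, but the data do not show that this core responds differently from the core of compound 1, nor do they show that the step carries over with a fixed size, and two cores are too few to settle either reading.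

The compounds shown leave open whether the same change would give a similar step on a third core. They also leave open how a nitrile or a methyl group on that same aromatic carbon would read in this assay on either core.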